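Notes on furan-3-yl replacing 2,4-dimethoxyphenyl

This account rests on a few compounds, and the source may have more. Where it says the series, first, only, none or still open, it means among the compounds named here.

compound 1 `C/C(=N\NC(N)=S)c1ccc2c(c1)nc(-c1ccc(C(F)(F)F)cc1)n2C1CCCCC1`: > 100000 nM (a limit)
compound 2 `COc1ccc(-c2nc3cc(/C(C)=N/NC(N)=S)ccc3n2C2CCCCC2)c(OC)c1`: 20000 nM

Going by the values given here, in an ADME assay on Vero cells (Chlorocebus sabaeus) for cytotoxicity, read by MTT assay, with a stated time of 96 h (a higher number here means that more compound is tolerated, a lower number that less compound is tolerated), compound 2 gives 20000 nM, the only actual number so far. The entry for compound 1 is a limit.

Compound 3 `C/C(=N\NC(N)=S)c1ccc2c(c1)nc(-c1ccoc1)n2C1CCCCC1` carries furan-3-yl in place of 2,4-dimethoxyphenyl on an aromatic carbon. Among the compounds with values here, one measured step bears on this change. A modest move to a higher number in this assay is expected because an at least 5.0-fold lower number from compound 1 to compound 2 (0.69 log units; beyond the scatter) came with the entry of 2,4-dimethoxyphenyl, the group that leaves here. Furan-3-yl itself has no measured value in this series.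

The expected step is a 2.3-fold higher number from compound 2 to compound 3 (0.35 log units; beyond the scatter). The estimate for compound 3 is 45000 nM, with an expected range from 15000 nM to 100000 nM.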

Compound 3, half-maximal cytotoxic concentration: 25000 nM
Estimate against measurement, compound 3: 1.8-fold (0.26 log units) above; measured number inside the range.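

In this assay the data show a 1.3-fold higher number from compound 2 to compound 3 (0.10 log units; within the scatter), so at this position furan-3-yl, with fewer heavy atoms, is not told apart from 2,4-dimethoxyphenyl. With furan-3-yl in place of 4-(trifluoromethyl)phenyl there is an at least 4.0-fold lower number from compound 1 to compound 3 (0.60 log units; beyond the scatter), so two different groups now share a step of this kind away from compound 1. The value for compound 1 is a limit, which leaves both of its steps bounded on one side only: the limit of > 100000 nM in this assay, at which 1 of the 3 values shown sits.

From the compounds shown here alone, the full size of those steps stays open. Also open, going by these compounds, is what an unsubstituted phenyl, a pyridine ring or an amine would give on this aromatic carbon.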